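This account rests on a few compounds, and the source may have more. Where it says the series, first, only, none or still open, it means among the compounds named here.

Among the compounds with values here, compound 2 `O=C(NOCc1ccccc1)c1cn(-c2ccccc2)nc1-c1ccc(Cl)cc1` stands at the higher of the two numbers so far: in a functional assay on A549 cells (Homo sapiens) for antiproliferative activity, read by MTT assay, with a stated time of 48 h, in the presence of a further agent that is not named here (on this read-out higher numbers stand for weaker inhibition of growth and lower numbers for stronger inhibition of growth), compound 2 gives 13000 nM, whereas compound 1 `Cc1ccc(-c2nn(-c3ccccc3)cc2C(=O)NOCc2ccccc2)cc1` gives 1140 nM. Within the data shown here, the only measured step, an 11-fold higher number from compound 1 to compound 2 (1.06 log units; beyond the scatter), concerns methyl against chloro. Compound 3 `O=C(NOCc1ccccc1)c1cn(-c2ccccc2)nc1-c1ccc(F)cc1` carries the change (fluoro in place of chloro on an aromatic carbon). Among the measured compounds shown here, no measured step covers this exchange; the single step available tells only that the substituent on this aromatic carbon matters strongly, not which way fluoro will go. A modest downward step is expected, a 2.6-fold lower number from compound 2 to compound 3 (0.41 log units; beyond the scatter), with wide uncertainty. For compound 3 the estimate is 5000 nM, within 1500 nM to 16000 nM.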

Compound 3, concentration for 50% growth inhibition: 10400 nM
Beside the measured number, compound 3's estimate is 2.1-fold (0.32 log units) below it, within the range that was stated.
By their numbers in this assay, from the lowest: compound 1; then compounds 3 and 2 (each within the scatter of the next).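

In this assay the change from 4-chlorophenyl to 4-fluorophenyl gives a 1.3-fold lower number from compound 2 to compound 3 (0.10 log units; within the scatter) and so does not separate the two halogens at this position. Fluoro in place of methyl gives a 9.1-fold higher number from compound 1 to compound 3 (0.96 log units; beyond the scatter) in the same direction as chloro, so the lower number of compound 1 now stands apart from both halogens, not from chloro alone. No evidence on the cause of this difference is available. From the compounds shown here alone, whether this gap is specific to methyl remains open. An ethyl group, a methoxy group or an amine on this aromatic carbon would test that.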